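Working notes: from compound 3 to compound 4

A few compounds are considered here, and "the series" means these few. Any claim that something is new, unique, unknown or untested is made for them only; others in the source may bear on it.

Measured in an ADME assay on WI-38 cells (Homo sapiens) for cytotoxicity, read by MTT assay, with a stated time of 72 h; on this read-out lower numbers stand for stronger inhibition and higher numbers for weaker inhibition:
compound 1 `O=C(CCc1cccc2c1B(O)OC2)Nc1ccccc1`: 30000 nM
compound 2 `O=C(CCc1cccc2c1B(O)OC2)Nc1cccc(I)c1`: 71000 nM
compound 3 `O=C(CCc1cccc2c1B(O)OC2)Nc1cccc(-c2cccc(Cl)c2)c1`: 58000 nM

Compound 3 stands within the scatter of both other compounds, as shown by a 1.9-fold higher number from compound 1 to compound 3 (0.29 log units; within the scatter) and a 1.2-fold lower number from compound 2 to compound 3 (0.09 log units; within the scatter). For the measured compounds named here, the only step beyond the scatter is modest: a 2.4-fold higher number from compound 1 to compound 2 (0.37 log units; beyond the scatter).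

The next compound is compound 4 `COc1cc(OC)cc(-c2cccc(NC(=O)CCc3cccc4c3B(O)OC4)c2)c1`. Its difference from compound 3 is 3,5-dimethoxyphenyl in place of 3-chlorophenyl on an aromatic carbon. In words, 3,5-dimethoxyphenyl stands in place of 3-chlorophenyl on an aromatic carbon, meta to a large group.

Going by the values given here, no measured step exchanges one substituted phenyl for another, so the evidence is indirect. The three measured steps all change the group at this same place. Two of them stay within the scatter, and the third only just clears it. On that basis, no step beyond the scatter is expected in this assay, and no direction is favoured with any confidence. The estimated step is a 1.2-fold lower number from compound 3 to compound 4 (0.06 log units; within the scatter). Compound 4 is expected at 50000 nM, with an estimated range of 25000 nM to 100000 nM.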

Compound 4, half-maximal inhibitory concentration: 1700 nM
The estimate for compound 4 lay 29-fold (1.47 log units) above the measured number; the measured number lies below the stated range.
By their numbers in this assay, from the lowest: compound 4; then compounds 1, 3 and 2 (each within the scatter of the next, the first and the last beyond it).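

In this assay, this position turns out to allow a large shift in the number, which the exchanges among hydrogen, iodo and 3-chlorophenyl did not show: 3,5-dimethoxyphenyl in place of 3-chlorophenyl gives a 34-fold lower number from compound 3 to compound 4 (1.53 log units; beyond the scatter). The shift holds against both other compounds, with a 42-fold lower number from compound 2 to compound 4 (1.62 log units; beyond the scatter) and an 18-fold lower number from compound 1 to compound 4 (1.25 log units; beyond the scatter), so compound 4 has the lowest number of the four, with each of its steps beyond the scatter. Both compound 3 and compound 4 carry a six-membered aromatic ring of carbon only at this place, so a second ring alone does not give the low number; the change lies in what that ring carries, with chlorine leaving and two methoxy groups entering, the entering group having hydrogen-bond acceptors and the leaving group none.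

Nothing available bears on the cause of this shift. The compounds shown leave open whether one methoxy group on the phenyl ring would be enough, and whether hydroxy groups or an amine in place of the methoxy groups would keep the number low.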